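Propyl on a Terminal Amine Nitrogen of Two Triamines

A few compounds are considered here, and "the series" means these few. Any claim that something is new, unique, unknown or untested is made for them only; others in the source may bear on it.

Measured so far in a functional assay on L1210 cells (Mus musculus) for inhibition, with a stated time of 48 h; on this read-out higher numbers stand for weaker inhibition and lower numbers for stronger inhibition:
Compound 1, `CCCNCCCNCCCN`: > 100000 nM
Compound 2, `CCCNCCCNCCCNCCC`: > 100000 nM
Compound 3, `CCCNCCCCNCCCCN`: 100000 nM

The value of compound 1 is a limit of this assay, not a number. The value of compound 2 is likewise a limit. Compound 2 differs from compound 1 by propyl in place of hydrogen on an amine nitrogen, and the step this made, a step that the two limits leave unreadable from compound 1 to compound 2, cannot be read because both compounds sit at the limit of > 100000 nM in this assay, at which 2 of the 3 values shown sit. Compound 3 is the only one of the three with a number. The difference between the core of compound 1 and the core of compound 3 is not broken down here.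

Compound 4, `CCCNCCCCNCCCCNCCC`, carries the same change on the core of compound 3: propyl in place of hydrogen on an amine nitrogen. Since the measured pair gives no readable size, the expectation for compound 4 rests on the value of compound 3, 100000 nM, and on the assumption that the propyl makes only a small step. The step from compound 3 to compound 4 is expected to be no change at the digits printed from compound 3 to compound 4 (within the scatter). Compound 4 is therefore estimated at 100000 nM, between 30000 nM and 300000 nM, with a fair chance that only a limit is reported.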

Compound 4, half-maximal inhibitory concentration: > 100000 nM
Compound 4: only a limit was reported (the forecaster's own chance of this, stated with the estimate: 55%); the middle value sits exactly at the limit.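

In this assay, propyl in place of hydrogen on an amine nitrogen of the core of compound 3 gives a number no lower from compound 3 to compound 4 (the limit leaves the size open). The value of compound 4, > 100000 nM, is a limit of the assay and not a number. The same change therefore ends at this limit on both cores, which shows that it carries over without giving a measurable value, but it does not show how large either step is or whether the two are alike, because the values crowd at one limit: the limit of > 100000 nM in this assay, at which 3 of the 4 values shown sit.

On these data alone, it remains open whether a shorter chain such as ethyl, or a longer chain such as butyl, on that amine nitrogen would give a number that can be read in this assay. Also open, as far as these compounds go, is whether propyl has the same effect on both cores, a question that needs a core whose value stands clear of the limit, with a readable number both before and after the change.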